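Changing the Aryl Amide Group and Mouse Microsomal Clearance

The source may hold more compounds than are shown below. What is called first, only, known or untested is meant among the compounds shown, and "the series" means these compounds.

Of the compounds shown here, three on one shared core have been measured in an in vitro ADME assay on microsomes from liver (Mus musculus) for pharmacokinetics, read by LC-MS, with a stated time of 10 min, tested at 1 uM; a higher number here means faster removal of the compound, a lower number slower removal. Compound 1 `CN1C[C@H](C(=O)Nc2ccc(C#N)cc2)[C@@H](c2ccc(/C=C/C(=O)Nc3ccccc3N)cc2)C1` gives 35 mL/min/kg. Compound 2 `CC(C)c1ccc(NC(=O)[C@H]2CN(C)C[C@@H]2c2ccc(/C=C/C(=O)Nc3ccccc3N)cc2)cc1` gives 54 mL/min/kg. Compound 3 `CN1C[C@H](C(=O)Nc2cccc(Cl)c2)[C@@H](c2ccc(/C=C/C(=O)Nc3ccccc3N)cc2)C1` gives 58 mL/min/kg, the highest of the three numbers, though both gaps to the others are within the scatter. Compound 4 `Cc1ccc(NC(=O)[C@H]2CN(C)C[C@@H]2c2ccc(/C=C/C(=O)Nc3ccccc3N)cc2)cn1` differs from compound 3 as follows: 6-methylpyridin-3-yl in place of 3-chlorophenyl on an amide-type nitrogen. The two steps that bear on this change, each altering the group on the amide-type nitrogen, were a 1.7-fold higher number from compound 1 to compound 3 (0.22 log units; within the scatter) and a 1.1-fold higher number from compound 2 to compound 3 (0.03 log units; within the scatter), both within the scatter. No step beyond the scatter is therefore expected for compound 4 in this assay. Compound 4 is expected to give 50 mL/min/kg, in a range from 25 mL/min/kg to 100 mL/min/kg, which means a 1.2-fold lower number from compound 3 to compound 4 (0.06 log units; within the scatter).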

Compound 4, clearance: 57 mL/min/kg
Beside the measured number, compound 4's estimate is 1.1-fold (0.06 log units) below it; low and high end bracket the measured number.
By their numbers in this assay, from the lowest: compounds 1, 2, 4 and 3 (each within the scatter of the next).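

In this assay the change to 6-methylpyridin-3-yl, the first ring here with a hetero atom and a hydrogen-bond acceptor, gives a 1.0-fold lower number from compound 3 to compound 4 (0.01 log units; within the scatter) and a 1.1-fold higher number from compound 2 to compound 4 (0.02 log units; within the scatter) and a 1.6-fold higher number from compound 1 to compound 4 (0.21 log units; within the scatter) on the amide-type nitrogen. All four aryl groups on this nitrogen, now including one that is not carbon-only, thus stay within the scatter of one another. Nothing shown gives a measured reason for these numbers. The compounds shown leave open whether a non-aromatic group on this nitrogen, such as an aliphatic amine or a carboxylic acid chain, would give a step beyond the scatter.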